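The source may hold more compounds than are shown below. What is called first, only, known or untested is meant among the compounds shown, and "the series" means these compounds.

Working notes on the series. Compound 1 `CS(=O)(=O)N(CC(=O)Nc1cccnc1F)c1ccccc1Cl` and compound 2 `CC(C(=O)Nc1cccc(Cl)c1)N(c1ccccc1Cl)S(C)(=O)=O` share the N-aryl sulfonamide core and have both been run in a functional assay on HEK293 cells for positive allosteric modulation of metabotropic glutamate receptor 5 (Rattus norvegicus), read by fluorescence and calcium flux; on this read-out higher numbers stand for an effect only at larger amounts of compound and lower numbers for an effect already at smaller amounts. In this assay, for the measured compounds named here, compound 1 gives 1740 nM; 1740 nM (2 entries), while compound 2 gives 68 nM; no single-point step links these two, so only the values themselves can be compared. Compound 2 stands as the only entry with a single number shown in this assay; one further entry for it carries no single number.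

Compound 3 `CCC(C(=O)Nc1cccc(Cl)c1)N(c1ccccc1Cl)S(C)(=O)=O` is not yet measured. It differs from compound 2 by methyl in place of hydrogen on a saturated chain carbon, two bonds along the chain from a carbonyl carbon and a sulfonamide nitrogen, that is, methyl to ethyl when the change is cut one bond further out. Going by the values given here, no step between measured compounds covers this change, so the expectation rests on the single value of compound 2 alone. For compound 3 the step of a 2.2-fold higher number from compound 2 to compound 3 (0.34 log units; beyond the scatter) is expected to be a modest loss, only slightly beyond the scatter. Compound 3 is therefore estimated at 150 nM in this assay, with a range from 40 nM to 600 nM.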

Compound 3, half-maximal effective concentration: 3300 nM
Compound 3: the middle estimate sits 22-fold (1.34 log units) below what was measured; the measured number lies above the stated range.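

In this assay, for the compounds shown here, this position proves far less tolerant than the single value of compound 2 could show: methyl in place of hydrogen on a saturated chain carbon, two bonds along the chain from a carbonyl carbon and a sulfonamide nitrogen, gives a 49-fold higher number from compound 2 to compound 3 (1.69 log units; beyond the scatter), well beyond the scatter. A change of one carbon, methyl to ethyl, is therefore enough at this position to shift the number by a large step. Nothing at hand accounts for the size of this step.

The compounds shown leave open whether a longer chain such as propyl at this carbon would raise the number further or whether the loss stops at ethyl. They also leave open how a hydroxymethyl group or a cyclopropyl ring would behave at the same place.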